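Chlorophenyl change from compound 2 to compound 4

The source may hold more compounds than are shown below. What is called first, only, known or untested is meant among the compounds shown, and "the series" means these compounds.

Compound 1 `CC1(C)CC(NC(=S)Nc2ccc(C#N)cc2)c2cc(F)ccc2O1`: 11000 nM
Compound 2 `CC1(C)CC(NC(=O)Nc2ccccc2Cl)c2cc(F)ccc2O1`: 40000 nM
Compound 3 `CC1(C)CC(NC(=O)Nc2ccccc2Cl)c2cc(Cl)ccc2O1`: 17000 nM

All three values come from a functional assay on U-373MG ATCC cells (Homo sapiens) for inhibition, read by MTT assay, with a stated time of 72 h; on this read-out lower numbers stand for stronger inhibition and higher numbers for weaker inhibition. Compound 2 stands highest of the three, at 40000 nM. The next candidate is compound 4 `CC1(C)CC(NC(=O)Nc2ccc(Cl)cc2)c2cc(F)ccc2O1`, which has the same atoms joined differently: 4-chlorophenyl in place of 2-chlorophenyl on an amide-type nitrogen, with 4-chlorophenyl in place of 2-chlorophenyl on an amide-type nitrogen. Among the measured compounds shown here, no measured step covers this change. For the measured compounds named here, the one measured step, a 2.4-fold lower number from compound 2 to compound 3 (0.37 log units; beyond the scatter), is modest and sits at a different place, so it offers only a rough guide to size. A modest move to a lower number is expected, though the direction is uncertain. The estimated step is a 2.2-fold lower number from compound 2 to compound 4 (0.35 log units; beyond the scatter). For compound 4 the expected value is 18000 nM, within an estimated range of 7000 nM to 45000 nM.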

Compound 4, half-maximal inhibitory concentration: 24000 nM
Compound 4: the middle estimate sits 1.3-fold (0.12 log units) below what was measured, and the stated range covers the measured number.
By their numbers in this assay, from the lowest: compounds 1, 3, 4 and 2 (each within the scatter of the next, the first and the last beyond it).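

In this assay, among the compounds shown here, 4-chlorophenyl in place of 2-chlorophenyl on the amide-type nitrogen gives a 1.7-fold lower number from compound 2 to compound 4 (0.22 log units; within the scatter), the first reading for this change of chlorine placement on the aryl group. With the fluoro core held fixed, this change cannot be told apart from repeat-measurement noise, so the two placements are not ranked. No available evidence bears on this result.

Going by these compounds, whether a methoxy group or an amine in place of the chlorine would move the number beyond the scatter stays open. Also open, on these data alone, is whether the same change behaves alike on the chloro core of compound 3.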